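Side-chain swap on compound 1: an expected potency step

The compounds below may be only part of what the source reports. "The series", "measured", "known", "first", "only" and "open" are said of these compounds alone.

Compound 1 `Cn1ncc(Cl)c1-c1cc(C(=O)N[C@@H]2CN[C@H](CC(O)CO)C[C@H]2c2ccc(Cl)c(Cl)c2)oc1Cl` gives 1610 nM in a functional assay on OVCAR-8 cells (Homo sapiens) for antiproliferative activity; a lower number here means a stronger inhibitor, a higher number a weaker inhibitor
Compound 2 `Cn1ncc(Cl)c1-c1cc(C(=O)N[C@@H]2CNCC[C@H]2c2ccc(C(F)(F)F)cc2)oc1Cl` gives 120 nM in this assay

Of these two numbers, compound 1 has the higher one, and the gap down to compound 2 lies beyond the usual scatter. The two compounds differ in more than one place, so that gap cannot be tied to any single group.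

Compound 3 `Cn1ncc(Cl)c1-c1cc(C(=O)N[C@@H]2CN[C@H](CCn3cncn3)C[C@H]2c2ccc(Cl)c(Cl)c2)oc1Cl` keeps the core of compound 1 and alters one side chain: (1H-1,2,4-triazol-1-yl)methyl in place of 1,2-dihydroxyethyl on a saturated chain carbon bound to a saturated ring carbon. In words, (1H-1,2,4-triazol-1-yl)methyl stands in place of 1,2-dihydroxyethyl on a saturated chain carbon bound to a saturated ring carbon.

Among the measured compounds shown here, no pair of measured compounds isolates this change, so the expectation is loose. A modest step toward a lower number in this assay is expected, since compound 2 at 120 nM shows that a much lower number is reachable in this series. The estimate amounts to a 2.3-fold lower number from compound 1 to compound 3 (0.36 log units; beyond the scatter) as the expected step. For compound 3 the estimated value is 700 nM, with an expected range from 200 nM to 2200 nM in this measurement.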

Compound 3, half-maximal inhibitory concentration: 1560 nM
For compound 3 the middle estimate is 2.2-fold (0.35 log units) below the measured one; the measured number falls inside the stated range.
By their numbers in this assay, from the lowest: compound 2; then compounds 3 and 1 (each within the scatter of the next).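

In this assay, among the compounds shown here, (1H-1,2,4-triazol-1-yl)methyl in place of 1,2-dihydroxyethyl on a saturated chain carbon bound to a saturated ring carbon gives a 1.0-fold lower number from compound 1 to compound 3 (0.01 log units; within the scatter), the only comparison here that isolates a single place. This shows that, with the rest of compound 1 held fixed, a group with no ring, 2 hydrogen-bond donors and 2 hydrogen-bond acceptors and a group with one five-membered aromatic ring, 0 hydrogen-bond donors and 3 hydrogen-bond acceptors leave the two compounds within the scatter of each other. No measurement given here accounts for this result.

As far as these compounds go, compound 2 gives 120 nM, but it differs from compound 1 in more than one place, so it remains open whether its lower number goes with the missing side chain or with trifluoromethyl in place of the two chlorines. From the compounds shown here alone, it is also open whether an amine or a carboxylic acid in place of 1,2-dihydroxyethyl would stay within the scatter of compound 1 and compound 3 or move beyond it.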